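The source may report more compounds than this note shows. Statements on the series, on what has been measured and on what is new or still open speak of the compounds shown alone.

Compound 1 `O=C(c1ccc([N+](=O)[O-])cc1)n1ccnc1-c1cccc([N+](=O)[O-])c1` and compound 2 `O=C(c1ccc([N+](=O)[O-])cc1)n1ccnc1-c1ccccc1[N+](=O)[O-]` share one core. In an ADME assay on HEL cells (Homo sapiens) for cytotoxicity (a lower number here means that less compound is tolerated, a higher number that more compound is tolerated), compound 1 reaches only a limit, > 100 ug/mL, not a number. In this assay compound 2 likewise reaches only a limit, > 100 ug/mL. Compound 2 thus stands at the limit of > 100 ug/mL in this assay, at which 2 of the 2 values shown sit, alongside the other value. Compound 3 `O=C(c1ccc([N+](=O)[O-])cc1)n1ccnc1-c1ccccc1Cl` carries chloro in place of nitro on an aromatic carbon. Among the compounds with values here, no step between measured compounds is known here. The step from compound 2 to compound 3 is expected to be a number no higher from compound 2 to compound 3 (the limit leaves the size open), none beyond the scatter. Compound 3 is therefore estimated at 100 ug/mL, within a range of 50 ug/mL to 200 ug/mL.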

Compound 3, minimum cytotoxic concentration: > 100 ug/mL
Compound 3: no number, only a limit; the forecaster's own chance of this, stated with the estimate: 75%; the middle value lies on the limit itself.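

In this assay, within the data shown here, compound 3 gives > 100 ug/mL, again a limit and not a number, so no step from compound 2 to compound 3 can be read. The compounds shown leave open at what concentration any of them would become cytotoxic: the limit of > 100 ug/mL in this assay, at which 3 of the 3 values shown sit.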